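The compounds below may be only part of what the source reports. "The series", "measured", "known", "first", "only" and "open" are said of these compounds alone.

Compound 1, `OC[C@H]1OC(n2cnc3c(SCc4ccccc4)nccc32)[C@H](O)[C@@H]1O`: in a functional assay on EL4 cells (Mus musculus) for inhibition, tested at 100 uM (a higher number here means more inhibition at the concentration tested (going by the name of the read-out), a lower number less inhibition), compound 1 gives 30%.
Compound 2, `OC[C@H]1OC(n2cnc3c(Cl)nccc32)[C@H](O)[C@@H]1O`: in this assay compound 2 gives only the assay's limit, < 5%.

Compound 2 thus stands at the floor of what this assay can resolve, with no number of its own; its value sits at the limit of < 5% in this assay, at which 1 of the 2 values shown sits. Among the compounds with values here, the step of a number at least 25 percentage points lower from compound 1 to compound 2 (beyond the scatter) is the only measured change so far: chloro in place of benzylsulfanyl removed a clear share of the inhibition. Compound 3, `CNc1nccc2c1ncn2C1O[C@H](CO)[C@@H](O)[C@H]1O`, differs from compound 2 in one place: methylamino in place of chloro on an aromatic carbon. Within the data shown here, no measured step involves a methylamino group, and the one step available concerns a different pair of groups, so it bears on this change only loosely; it shows that the chloro compound lies at the floor and that a larger group on the shared core once gave more inhibition. Any move from compound 2 can only be upward or flat. The step of a number at least 5 percentage points higher from compound 2 to compound 3 (that floor lies within the scatter) is expected to be small, if it appears at all. Compound 3 is therefore estimated at 10%, with a range of 0% to 35%.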

Compound 3, a percentage reported as inhibition, at one concentration (the size of the read-out at that concentration, not a potency): 11%
Beside the measured number, compound 3's estimate is 1 percentage points below it, within the range that was stated.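

At this aromatic carbon, next to the ring nitrogen, the step of a number at least 6 percentage points higher from compound 2 to compound 3 (that floor lies within the scatter) cannot be read as a real gain for methylamino over chloro, even though methylamino brings a hydrogen-bond donor and chloro brings none. Compound 2 remains at a limit of the assay rather than a number, leaving the true size of that step unknown: the limit of < 5% in this assay, at which 1 of the 3 values shown sits.

The clearer new finding is the step of a number 19 percentage points lower from compound 1 to compound 3 (beyond the scatter), which shows that in this assay methylamino does not match benzylsulfanyl at this position, so having just any group larger than chloro here is not enough to reach the inhibition seen with benzylsulfanyl.

Benzylsulfanyl and methylamino differ both in the atom attached to the ring, sulfur or nitrogen, and in what that atom carries, so these compounds cannot say which of the two features accounts for the difference. A benzylamino group, which keeps the benzyl part on a nitrogen, and a methylsulfanyl group, which keeps the sulfur with only a methyl on it, would separate the two features.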